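Cyano in Place of Chloro: What to Expect Next

The source may report more compounds than this note shows. Statements on the series, on what has been measured and on what is new or still open speak of the compounds shown alone.

Three compounds have been measured in an assay on isolated protein for inhibition of fatty acid synthase (Mus musculus), read by spectrophotometry, using NADPH, with stated times of 30 min and 3 min, in the presence of a further agent that is not named here; a lower number here means a stronger inhibitor, a higher number a weaker inhibitor:

compound 1, `CCCCCC(=O)O[C@H]1C(=O)OCC1(C)C`, gives 23300 nM
compound 2, `CCCCCCCC(=O)O[C@H]1C(=O)OCC1(C)C`, gives 20800 nM
compound 3, `CC1(C)COC(=O)[C@@H]1OC(=O)c1ccc(Cl)cc1`, gives 19200 nM

All three share the same core and differ only in the acid part of the ester. Among the measured compounds shown here, the single step between compounds that differ in one place, a 1.1-fold lower number from compound 1 to compound 2 (0.05 log units; within the scatter), lengthens a saturated chain and stays within the scatter. Compound 3 carries an aromatic ring rather than a chain; it shows the lowest of the three numbers, yet its gap to compound 2 and to compound 1 is within the scatter, so the three cannot be set apart from one another.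

Compound 4, `CC1(C)COC(=O)[C@@H]1OC(=O)c1ccc(C#N)cc1`, is not yet measured. It differs from compound 3 in one place: cyano in place of chloro on an aromatic carbon. For the measured compounds named here, no measured step touches the aromatic ring, and the one chain step gave no shift, so there is no basis to expect a move beyond the scatter in this assay. Compound 4 is therefore expected to give 19000 nM, with a range from 8000 nM to 45000 nM. This estimate corresponds to an expected step of a 1.0-fold lower number from compound 3 to compound 4 (0.00 log units; within the scatter), essentially no change.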

Compound 4, half-maximal inhibitory concentration: 21500 nM
Estimate against measurement, compound 4: 1.1-fold (0.05 log units) below, within the range that was stated.
By their numbers in this assay, from the lowest: compounds 3, 2, 4 and 1 (each within the scatter of the next).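

In this assay, the first change made on the aromatic ring gives a 1.1-fold higher number from compound 3 to compound 4 (0.05 log units; within the scatter). Cyano in place of chloro on this aromatic carbon, para to a large group, therefore leaves compound 3 and compound 4 within the usual scatter of each other. The swap replaces a single chlorine atom with a group of two heavy atoms that holds a triple bond and a hydrogen-bond acceptor, yet this difference in structure brings no readable change in this assay. No measurement is available that could explain why the two compounds read alike.

Going by these compounds, whether any group on this aromatic carbon can move the number beyond the scatter stays open, and an amine or a carboxylic acid there would test this. Also open, on these data alone, is whether a much longer chain in the acid part of the ester would separate itself from compound 1 and compound 2.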